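Replacing nitro with fluoro: working notes toward compound 4

The source may hold more compounds than are shown below. What is called first, only, known or untested is meant among the compounds shown, and "the series" means these compounds.

Measured in a functional assay on T47D cells (Homo sapiens) for cytotoxicity, read by MTT assay; a higher number here means a weaker inhibitor, a lower number a stronger inhibitor:
compound 1 `O=C(/C=C/c1ccc(N2CCCC2)cc1)c1ccc([N+](=O)[O-])cc1` gives 21300 nM
compound 2 `O=C(/C=C/c1ccc(F)cc1)c1ccc(O)cc1O` gives 8310 nM
compound 3 `COc1cc(O)ccc1C(=O)/C=C/c1ccc(F)cc1` sits at a limit, > 25000 nM

Among the two numbers in hand, compound 1 gives the higher one and compound 2 the lower, a gap beyond the scatter. Compound 3 is not a number at all but a limit of the assay, (the limit of > 25000 nM in this assay, at which 1 of the 3 values shown sits). For the measured compounds named here, the one step measured between compounds differing in one place is an at least 3.0-fold higher number from compound 2 to compound 3 (0.47 log units; beyond the scatter); it concerns methyl in place of hydrogen on an oxygen on an aromatic ring and says nothing about the change now in view.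

Compound 4 `O=C(/C=C/c1ccc(N2CCCC2)cc1)c1ccc(F)cc1` differs from compound 1 in this way: fluoro in place of nitro on an aromatic carbon. Going by the values given here, no measured step bears on a fluoro-for-nitro exchange here, so no direction can be read off the series. With nothing to lean on, a step not beyond the scatter is expected in this assay, that is a 1.1-fold lower number from compound 1 to compound 4 (0.03 log units; within the scatter). Compound 4 is therefore estimated at 20000 nM, between 6000 nM and 60000 nM.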

Compound 4, half-maximal inhibitory concentration: > 25000 nM
Compound 4 was reported as a limit; the forecaster's own chance of this, stated with the estimate: 35%; middle value at least 1.2-fold (0.09 log units) from the limit.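

In this assay, fluoro in place of nitro on this aromatic carbon gives an at least 1.1-fold higher number from compound 1 to compound 4 (0.06 log units; that floor lies within the scatter), so nothing here shows fluoro doing better than nitro at this position, though the floor alone does not show it doing worse. Compound 4 stands at a limit of the assay, > 25000 nM, and not at a number. The size of the step therefore stays unread, since the exchange carries the series to the end of the measurable range, where the pair gives only a floor: the limit of > 25000 nM in this assay, at which 2 of the 4 values shown sit.

Going by these compounds, whether another group on this carbon, such as an amine, a carboxylic acid or a nitrile, would give a lower number than nitro remains open. Also open, on these data alone, is whether the same exchange would behave alike on a core without the pyrrolidine-bearing ring of compound 1.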